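Sulfonamide series: replacing the ring-nitrogen substituent

This account rests on a few compounds, and the source may have more. Where it says the series, first, only, none or still open, it means among the compounds named here.

Measured so far:
compound 1 `O=C(c1ccc(C(F)(F)F)cc1)N1CCC(NS(=O)(=O)c2cc(S(=O)(=O)c3ccccc3)ccc2C(F)(F)F)CC1` gives 400 nM in an assay on isolated protein for displacement of a labelled ligand from secreted frizzled-related protein 1 (Homo sapiens), read by fluorescence polarization, with a stated time of 30 min; on this read-out higher numbers stand for weaker inhibition and lower numbers for stronger inhibition
compound 2 `N#Cc1cccc(S(=O)(=O)N2CCC(NS(=O)(=O)c3cc(S(=O)(=O)c4ccccc4)ccc3C(F)(F)F)CC2)c1` gives 90 nM in this assay

Compound 2 holds the lowest number of the two, with compound 1 the nearer neighbour by a gap of a 4.4-fold lower number from compound 1 to compound 2 (0.65 log units; beyond the scatter). Among the measured compounds shown here, that single step, a modest one beyond the scatter, is the only comparison available and covers a change at the same ring nitrogen.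

Compound 3 `O=C(O)c1ccc(N2CCC(NS(=O)(=O)c3cc(S(=O)(=O)c4ccccc4)ccc3C(F)(F)F)CC2)cc1` differs from compound 2 in that position: 4-carboxyphenyl in place of (3-cyanophenyl)sulfonyl on an amine nitrogen in a ring. For the measured compounds named here, no measured step exchanges a sulfonyl-linked ring for a ring bound directly to the nitrogen, and none brings in a carboxylic acid, so the step from compound 1 to compound 2 bears on it only loosely. The expectation is therefore set near the middle of the two measured numbers with a wide range. For compound 3 the estimated step is a 3.3-fold higher number from compound 2 to compound 3 (0.52 log units; beyond the scatter) in this assay, giving an expected value of 300 nM in this assay, between 60 nM and 1500 nM.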

Compound 3, half-maximal inhibitory concentration: 120 nM
For compound 3 the middle estimate is 2.5-fold (0.40 log units) above the measured one, within the range that was stated.
By their numbers in this assay, from the lowest: compounds 2 and 3 (each within the scatter of the next); then compound 1.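

In this assay, the ring nitrogen accepts a 4-carboxyphenyl bound directly to it in place of the (3-cyanophenyl)sulfonyl, with a 1.3-fold higher number from compound 2 to compound 3 (0.12 log units; within the scatter), so neither the sulfonyl link nor the nitrile is required for a value at this level. The same group also separates from the (4-(trifluoromethyl)phenyl)carbonyl of the first compound, with a 3.3-fold lower number from compound 1 to compound 3 (0.52 log units; beyond the scatter), so two quite different substituents on this nitrogen now give lower numbers than that carbonyl-linked group. No supporting data are available to account for these steps.

The compounds shown leave open whether the carboxylic acid contributes at all, since an unsubstituted phenyl, a methyl ester or a primary amide at this nitrogen would be needed to tell. Also open, as far as these compounds go, is how a longer chain between the ring and the carboxylic acid would read.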